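The source may report more compounds than this note shows. Statements on the series, on what has been measured and on what is new or still open speak of the compounds shown alone.

Of the compounds shown here, three have so far been tested in a functional assay on HEK293 cells for agonist activity at Free fatty acid receptor 1 (Homo sapiens), read by fluorescence and calcium flux; on this read-out lower numbers stand for an effect already at smaller amounts and higher numbers for an effect only at larger amounts of compound. Compound 1 `CC#CC(CC(=O)O)c1ccc(OCc2ccc(C(=O)N3CCc4ccccc4C3)s2)cc1` gives 57 nM. Compound 2 `CC#CC(CC(=O)O)c1ccc(OCc2ccc(C(=O)NC3CCCc4ccccc43)s2)cc1` carries (1,2,3,4-tetrahydronaphthalen-1-yl)amino in place of 1,2,3,4-tetrahydroisoquinolin-2-yl on a carbonyl carbon and gives 109 nM in this assay; the step between them is a 1.9-fold higher number from compound 1 to compound 2 (0.28 log units; within the scatter). Compound 3 `CC#CC(CC(=O)O)c1ccc(OCc2cnc(C(=O)N3CCc4ccccc4C3)s2)cc1` rests on a different core, and the difference between the two cores is not broken down here. In this assay compound 3 gives 531 nM, the highest of the three numbers, standing beyond the scatter from both compound 1 and compound 2.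

Compound 4 `CC#CC(CC(=O)O)c1ccc(OCc2cnc(C(=O)NC3CCCc4ccccc43)s2)cc1` has not yet been measured. It differs from compound 3 by (1,2,3,4-tetrahydronaphthalen-1-yl)amino in place of 1,2,3,4-tetrahydroisoquinolin-2-yl on a carbonyl carbon, the same change as that between compound 1 and compound 2, made at the same place. Because the same change gave a 1.9-fold higher number from compound 1 to compound 2 (0.28 log units; within the scatter), a step of similar size is expected for compound 4, namely a 1.9-fold higher number from compound 3 to compound 4 (0.27 log units; within the scatter). Compound 4 is therefore estimated to give about 1000 nM in this assay. Its number is expected to fall between 350 nM and 3000 nM.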

Compound 4, half-maximal effective concentration: 144 nM
Beside the measured number, compound 4's estimate is 6.9-fold (0.84 log units) above it; measured number below the stated range.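

On the core of compound 3, (1,2,3,4-tetrahydronaphthalen-1-yl)amino in place of 1,2,3,4-tetrahydroisoquinolin-2-yl on a carbonyl carbon gives a 3.7-fold lower number from compound 3 to compound 4 (0.57 log units; beyond the scatter) in this assay. Set beside the earlier step, this shows that the change does not carry over from one core to the other with the same effect: the same change on two cores in this assay, a 1.9-fold higher number (0.28 log units; within the scatter) from compound 1 to compound 2 and a 3.7-fold lower number (0.57 log units; beyond the scatter) from compound 3 to compound 4, 7.1-fold (0.85 log units) apart, beyond the scatter of two such steps What the change does in this series therefore depends on the core in these two pairs, but two pairs give no general rule for other cores, and they do not show what in the two cores separates the outcomes.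

The compounds shown leave open how a piperidin-1-yl or a benzylamino group on the same carbonyl carbon would behave on the core of compound 1 and on the core of compound 3. They also leave open whether a third core would follow either of these two steps or take a course of its own.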